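The source may hold more compounds than are shown below. What is called first, only, known or untested is meant among the compounds shown, and "the series" means these compounds.

Three compounds have so far been measured in an assay on HEK cells for inhibition of Tryptophan 2,3-dioxygenase (Homo sapiens); a lower number here means a stronger inhibitor, a higher number a weaker inhibitor:

Compound 1 `O=C(Nc1ccc(Cl)cc1)C(=O)N1CCC(c2ccnc3ccc(F)cc23)CC1` gives 6900 nM.
Compound 2 `N#Cc1ccc(NC(=O)C(=O)N2CCC(c3ccnc4ccc(F)cc34)CC2)cc1` gives 5500 nM.
Compound 3 `O=C(Nc1ccc(C(F)F)cc1)C(=O)N1CCC(c2ccnc3ccc(F)cc23)CC1` gives 5800 nM.

Compound 1 sits alongside the other two: a 1.3-fold lower number from compound 1 to compound 2 (0.10 log units; within the scatter) and a 1.2-fold lower number from compound 1 to compound 3 (0.08 log units; within the scatter), and likewise a 1.1-fold higher number from compound 2 to compound 3 (0.02 log units; within the scatter), so the three cannot be told apart on these numbers.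

Compound 4 `O=C(Nc1ccc(Cl)cc1)C(=O)N1CC[C@@H](c2ccnc3ccc(F)cc23)[C@H](O)C1` differs from compound 1 by hydroxy in place of hydrogen on a saturated ring carbon. None of the three measured steps touches this part of the shared core; each of them swaps the group on the aromatic ring of the anilide, and each stayed within the scatter. Among the compounds with values here, the step to compound 4 is therefore of a kind for which the measured compounds give no direct precedent, and they show only that the anilide substituent can be varied without moving the read-out in this assay. With nothing to point in either direction, compound 4 is expected to land close to compound 1, with a 1.0-fold higher number from compound 1 to compound 4 (0.01 log units; within the scatter) as the best guess and a wide allowance for an unprecedented change. The estimate for compound 4 in this assay is 7000 nM, ranging from 1500 nM to 30000 nM.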

Compound 4, half-maximal inhibitory concentration: 15300 nM
For compound 4 the middle estimate is 2.2-fold (0.34 log units) below the measured one; the measured number falls inside the stated range.
By their numbers in this assay, from the lowest: compounds 2, 3 and 1 (each within the scatter of the next); then compound 4.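

In this assay, placing hydroxy in place of hydrogen on the saturated ring carbon gives a 2.2-fold higher number from compound 1 to compound 4 (0.35 log units; beyond the scatter), a modest step but the only one in this set that lies beyond the scatter. The three earlier steps all changed the group on the aromatic carbon and could not be told apart, whereas this one shows that the read-out responds to a change on the six-membered non-aromatic ring, at a carbon next to the ring atom that bears a large group and two ring bonds from the ring nitrogen, with the number moving towards a weaker inhibitor. No measurement at hand speaks to the origin of this step.

The compounds shown leave open whether the change in the number is specific to hydroxy or would also follow a methoxy group or an amine on the same ring carbon, and whether other spatial arrangements of the hydroxy would behave alike. They also leave open whether the same step would appear with the nitrile of compound 2 or the difluoromethyl of compound 3 in place of chloro.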